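A few compounds are considered here, and "the series" means these few. Any claim that something is new, unique, unknown or untested is made for them only; others in the source may bear on it.

Of the compounds shown here, three sharing one core have been measured in an assay for inhibition of serine/threonine-protein kinase PAK 4 (Homo sapiens), read by FRET and Z'-LYTE, with a stated time of 60 min, tested at 50 uM, in the presence of a further agent that is not named here; on this read-out higher numbers stand for a stronger effect at the one concentration tested and lower numbers for a weaker effect. Compound 1 `CC(C)C(=O)OCOC(=O)N1CCN(C(=O)c2nc(Nc3cc(C4CC4)[nH]n3)c3cc(Cl)ccc3n2)C[C@H]1C` gives 86.9%. Compound 2 `C[C@@H]1CN(C(=O)c2nc(Nc3cc(C4CC4)[nH]n3)c3cc(Cl)ccc3n2)CCN1C(=O)OC(C)(C)C` gives 36.4%. Compound 3 `CC(OC(=O)C(C)C)OC(=O)N1CCN(C(=O)c2nc(Nc3cc(C4CC4)[nH]n3)c3cc(Cl)ccc3n2)C[C@H]1C` gives 71.7% and stands second of the three, under compound 1 and over compound 2, both gaps beyond the scatter. The step of a number 15.2 percentage points lower from compound 1 to compound 3 (beyond the scatter) was modest, while the step of a number 35.3 percentage points higher from compound 2 to compound 3 (beyond the scatter) was large.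

Compound 4 `CCOC(=O)N1CCN(C(=O)c2nc(Nc3cc(C4CC4)[nH]n3)c3cc(Cl)ccc3n2)C[C@H]1C` has not yet been measured. It differs from compound 3 in one place: hydrogen in place of (isopropylcarbonyl)oxy on a saturated chain carbon bound to an oxygen next to a carbonyl group and a saturated chain carbon. Among the measured compounds shown here, two measured steps bear on this change. The step of a number 35.3 percentage points higher from compound 2 to compound 3 (beyond the scatter) shows that 1-((isopropylcarbonyl)oxy)ethyl on an oxygen next to a carbonyl group gave a far higher number than tert-butyl, and the step of a number 15.2 percentage points lower from compound 1 to compound 3 (beyond the scatter) shows that ((isopropylcarbonyl)oxy)methyl at the same oxygen scored higher still. Compound 4 keeps only ethyl at that oxygen, which makes it resemble compound 2 more than compound 3 in this respect, so a downward step beyond the scatter is expected. For compound 4 the expected step is a number 26.7 percentage points lower from compound 3 to compound 4 (beyond the scatter). Compound 4 is therefore estimated to give about 45%, within a range from 25% to 68%.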

Compound 4, a percentage reported as inhibition, at one concentration (the size of the read-out at that concentration, not a potency): 93.4%
Beside the measured number, compound 4's estimate is 48.4 percentage points below it, and the stated range ends below it.
By their numbers in this assay, from the lowest: compound 2; then compound 3; then compounds 1 and 4 (each within the scatter of the next).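

In this assay the step of a number 21.7 percentage points higher from compound 3 to compound 4 (beyond the scatter) shows that taking (isopropylcarbonyl)oxy off this saturated chain carbon does not lower the number, so that group is not needed for a high reading in this series. Among the compounds shown here, until now, tert-butyl was the only group at this oxygen without (isopropylcarbonyl)oxy, but the step of a number 57 percentage points higher from compound 2 to compound 4 (beyond the scatter) separates the two: the low reading of compound 2 goes with tert-butyl itself and not with the lack of (isopropylcarbonyl)oxy. The step of a number 6.5 percentage points higher from compound 1 to compound 4 (within the scatter) means that ethyl and ((isopropylcarbonyl)oxy)methyl cannot be told apart at this oxygen in this read-out, and no data at hand speak to the reason for any of these steps.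

The compounds shown leave open whether methyl, isopropyl or a longer chain such as n-butyl at this oxygen would stay with ethyl or fall towards tert-butyl, and so where along that series the number drops. With a single concentration tested, they also leave open how the potencies of compound 1 and compound 4 compare.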